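A few compounds are considered here, and "the series" means these few. Any claim that something is new, unique, unknown or untested is made for them only; others in the source may bear on it.

Measured compounds in an assay on CHO cells for displacement of a labelled ligand from C-X-C chemokine receptor type 1 (Homo sapiens); a higher number here means a weaker inhibitor, a lower number a stronger inhibitor:
- compound 1, `CC[C@@H](Nc1c(Nc2cccc(C(=O)N(C)C)c2O)c(=O)c1=O)c1cc(C)cs1`; compound 1 gives 24 nM
- compound 2, `CCc1ccoc1[C@@H](CC)Nc1c(Nc2cccc(C(=O)N(C)C)c2O)c(=O)c1=O`; compound 2 gives 379 nM
- compound 3, `CC[C@@H](Nc1c(Nc2cccc(C(=O)N(C)C)c2O)c(=O)c1=O)c1cc(C(C)C)co1`; compound 3 gives 3 nM

Compound 3 stands lowest of the three numbers in this assay. The step of an 8.0-fold lower number from compound 1 to compound 3 (0.90 log units; beyond the scatter) and the step of a 130-fold lower number from compound 2 to compound 3 (2.10 log units; beyond the scatter) both lie beyond the scatter, as does the step of a 16-fold higher number from compound 1 to compound 2 (1.20 log units; beyond the scatter). All three measured steps exchange the whole group on the saturated chain carbon bound to the nitrogen; none of them changes only the substituent on the furan ring while keeping the ring itself.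

Compound 4, `CC[C@@H](Nc1c(Nc2cccc(C(=O)N(C)C)c2O)c(=O)c1=O)c1cc(C2CCCC2)co1`, differs from compound 3 by cyclopentyl in place of isopropyl on an aromatic carbon. Going by the values given here, no measured step bears directly on this exchange. Among the compounds with values here, the only indication that a change at that position is tolerated comes from compound 1 and compound 3, where a different ring was also exchanged, so it cannot be separated. The expectation is therefore a step no larger than the scatter, no change at the digits printed from compound 3 to compound 4 (within the scatter), in either direction, with compound 3 as the anchor.

Compound 4 is estimated at 3 nM in this assay, with a range from 1 nM to 10 nM.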

Compound 4, inhibition constant: 53 nM
Beside the measured number, compound 4's estimate is 18-fold (1.25 log units) below it; measured number outside the range, above it.
By their numbers in this assay, from the lowest: compound 3; then compound 1; then compound 4; then compound 2.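

In this assay, going by these compounds alone, this carbon of the furan, two ring bonds from the ring oxygen, proves sensitive to its substituent: with the ring kept, cyclopentyl in place of isopropyl gives an 18-fold higher number from compound 3 to compound 4 (1.25 log units; beyond the scatter), the first step that isolates this position. Across ring exchanges, the 4-cyclopentylfuran-2-yl group still improves on 3-ethylfuran-2-yl, with a 7.2-fold lower number from compound 2 to compound 4 (0.85 log units; beyond the scatter), but it falls behind 4-methylthiophen-2-yl, with a 2.2-fold higher number from compound 1 to compound 4 (0.34 log units; beyond the scatter), so the gain that compound 3 holds over compound 1 does not carry over to compound 4. Nothing available explains this loss at the furan position.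

The compounds shown leave open whether the number follows the added carbons or the closed ring, a question that a cyclopropyl or a tert-butyl group at the same carbon, or an open pentyl chain, would help to settle. They also leave open whether an amine or a carboxylic acid is accepted at this carbon, and whether cyclopentyl in place of methyl on the thiophene would give a step of the same direction.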